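This account rests on a few compounds, and the source may have more. Where it says the series, first, only, none or still open, it means among the compounds named here.

Working notes on the series. Compound 3 `CS(=O)(=O)Nc1ccc(NC(=O)c2ccc(Cl)cc2)cc1Cl` gives 167000 nM in an ADME assay on HEK293 cells (Homo sapiens) for cytotoxicity, read by MTT assay, with a stated time of 48 h (on this read-out lower numbers stand for stronger inhibition and higher numbers for weaker inhibition), the highest of the two numbers recorded so far. The nearest number is that of compound 1 `Cc1cc(NC(=O)c2ccc(C#N)cc2)ccc1NS(C)(=O)=O`, which in this assay gives 43500 nM. Compound 2 `COc1cc(NC(=O)c2ccc(C#N)cc2)ccc1NS(C)(=O)=O` reaches only a limit of the assay: in this assay compound 2 gives > 250000 nM. Within the data shown here, the one single-point step measured so far, an at least 5.7-fold higher number from compound 1 to compound 2 (0.75 log units; beyond the scatter), concerns the ring that carries the methanesulfonamide and not the benzoyl ring.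

Compound 4 `CS(=O)(=O)Nc1ccc(NC(=O)c2ccc(C#N)cc2)cc1Cl` is the next member, differing from compound 3 as follows: cyano in place of chloro on an aromatic carbon, on an aromatic carbon of a six-membered aromatic ring of carbon only, para to a large group. Among the measured compounds shown here, no measured step exchanges chloro for cyano at this place, so none bears on it directly; compound 1 and compound 3 differ at two places and show only that the cyano-bearing compound 1 sits lower. The expectation for compound 4 is therefore a step of uncertain direction, a 1.4-fold lower number from compound 3 to compound 4 (0.14 log units; within the scatter), and likely of small size. Compound 4 is estimated at 120000 nM in this assay, with a range from 40000 nM to 300000 nM.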

Compound 4, half-maximal inhibitory concentration: > 250000 nM
Compound 4: only a limit was reported; the forecaster's own chance of this, stated with the estimate: 25%; at least 2.0-fold (0.31 log units) between middle value and limit.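

With cyano in place of chloro, para to a large group, this assay gives an at least 1.4-fold higher number from compound 3 to compound 4 (0.17 log units; that floor lies within the scatter), so the chloro compound's number is not shown to be lowered by this change, and the size of any rise cannot be read from a floor within the scatter. On the ring carrying the methanesulfonamide, chloro in place of methyl gives an at least 5.7-fold higher number from compound 1 to compound 4 (0.75 log units; beyond the scatter), a second exchange away from methyl on that ring alongside an at least 5.7-fold higher number from compound 1 to compound 2 (0.75 log units; beyond the scatter). Among these compounds, of the three compounds with cyano on the benzoyl ring, compound 1 alone now gives a number rather than a limit, so methyl is the only group on that ring in these cyano compounds whose effect stands as a measured value.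

From the compounds shown here alone, the step between compound 2 and compound 4 cannot be read, because both values are limits: the limit of > 250000 nM in this assay, at which 2 of the 4 values shown sit. Whether an amine or a carboxylic acid at the cyano position, or an ethyl group in place of the methyl of compound 1, would give a number rather than a limit stays open, as does the order of methoxy and chloro on the ring carrying the methanesulfonamide.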